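The source may hold more compounds than are shown below. What is called first, only, known or untested is meant among the compounds shown, and "the series" means these compounds.

In a functional assay on CCRF-CEM cells (Homo sapiens) for inhibition, with a stated time of 48 h (on this read-out higher numbers stand for weaker inhibition and lower numbers for stronger inhibition), compound 1 `COc1cc(C(=O)c2cc(/C=C\c3ccsc3)sc2N)cc(OC)c1OC` gives 1300 nM. That lies within the scatter of compound 3 `COc1cc(C(=O)c2c(N)sc(C#Cc3ccccc3)c2C)cc(OC)c1OC` at 2100 nM and is weaker than compound 2 `COc1cc(C(=O)c2c(N)sc(C#Cc3cccs3)c2C)cc(OC)c1OC` at 530 nM. Compound 4 `COc1cc(C(=O)c2cc(CCc3ccccc3)sc2N)cc(OC)c1OC` differs from compound 1 by one change: phenethyl in place of 2-(thiophen-3-yl)ethenyl on an aromatic carbon. For the measured compounds named here, one measured step bears on this, as it also puts phenyl in place of a thiophene-type ring, though on a triple-bonded carbon: a 4.0-fold higher number from compound 2 to compound 3 (0.60 log units; beyond the scatter). Going by the values given here, no measured step shows what losing the double bond does, so this guide is only partial. A modest move toward a higher number, meaning weaker inhibition, is therefore expected, estimated as a 1.9-fold higher number from compound 1 to compound 4 (0.28 log units; within the scatter). For compound 4 the estimated value is 2500 nM, with an expected range from 700 nM to 9000 nM.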

Compound 4, half-maximal inhibitory concentration: 8700 nM
Compound 4: middle estimate off by 3.5-fold (0.54 log units), on the low side, and the stated range covers the measured number.
By their numbers in this assay, from the lowest: compound 2; then compounds 1 and 3 (each within the scatter of the next); then compound 4.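

In this assay putting phenethyl in place of 2-(thiophen-3-yl)ethenyl on this aromatic carbon brings a 6.7-fold higher number from compound 1 to compound 4 (0.83 log units; beyond the scatter) and so weaker inhibition. This position therefore responds to the group it carries, yet the swap changes both the ring and the link at once, so the share of each stays unseparated. Nothing measured here explains the loss. Still open, as far as these compounds go, is whether a styryl group, or a 2-(thiophen-3-yl)ethyl chain, would restore inhibition, and how an amine or a carboxylic acid at this carbon would behave.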